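From cyclohexyl amide to chlorophenyl amine on a shared core

This account rests on a few compounds, and the source may have more. Where it says the series, first, only, none or still open, it means among the compounds named here.

For the measured compounds named here, compound 2 `C[C@@H](C(=O)NC1CCCCC1)[C@H]1CC[C@@H](c2ccnc3ccc(F)cc32)CC1` gives 287 nM in an assay on tissue (M109 cells) for inhibition of Indoleamine 2,3-dioxygenase 1 (Mus musculus), with stated times of 2 h and 18 h (a higher number here means a weaker inhibitor, a lower number a stronger inhibitor), the lowest of the two numbers recorded; its only neighbour, compound 1 `C[C@H](NC(=O)[C@H](C)[C@H]1CC[C@@H](c2ccnc3ccc(F)cc32)CC1)c1ccc(Cl)cc1`, gives 870 nM, and the step is a 3.0-fold lower number from compound 1 to compound 2 (0.48 log units; beyond the scatter). Compound 3 `C[C@@H](CNc1ccc(Cl)cc1)[C@H]1CC[C@@H](c2ccnc3ccc(F)cc32)CC1` has not been measured. It differs from compound 2 by ((4-chlorophenyl)amino)methyl in place of cyclohexylcarbamoyl on a saturated chain carbon bound to a saturated chain carbon and a saturated ring carbon, so the amide carbonyl is gone and an aniline-type nitrogen takes its place. Going by the values given here, no measured step covers this change. Among the compounds with values here, the one step known, from compound 1 to compound 2, concerns only a swap of the group on the amide nitrogen and is modest, so it offers little guidance for removing the amide altogether. The replacement is therefore judged with wide uncertainty; a weakening is considered somewhat more likely than a gain. Compound 3 is expected to give about 600 nM in this assay, between 120 nM and 3000 nM, a step of a 2.1-fold higher number from compound 2 to compound 3 (0.32 log units; beyond the scatter).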

Compound 3, half-maximal inhibitory concentration: 62 nM
Compound 3: middle estimate off by 9.7-fold (0.99 log units), on the high side; the whole stated range lies above it.
By their numbers in this assay, from the lowest: compound 3; then compound 2; then compound 1.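

At this saturated chain carbon bound to a saturated chain carbon and a saturated ring carbon, the amide proves dispensable in this assay: with ((4-chlorophenyl)amino)methyl in place of cyclohexylcarbamoyl, the change is a 4.6-fold lower number from compound 2 to compound 3 (0.67 log units; beyond the scatter) and the carbonyl is gone. The earlier step had only exchanged the group on the amide nitrogen, whereas this one shows that the whole linker can be replaced with a gain, leaving compound 3 at 62 nM, the lowest of the three numbers in this assay. Nothing measured among these data accounts for that gain.

As far as these compounds go, the step changes the linker and the ring together, so the share of each stays unknown. A (cyclohexylamino)methyl group or a (4-chlorophenyl)carbamoyl group at this carbon would separate the two.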